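Series notes: ethoxy to isopropoxy step, compounds 3 and 4

A few compounds are considered here, and "the series" means these few. Any claim that something is new, unique, unknown or untested is made for them only; others in the source may bear on it.

Measured so far in a functional assay on A549 cells (Homo sapiens) for antiproliferative activity, read by sulforhodamine B assay, with a stated time of 72 h; a higher number here means a weaker inhibitor of growth, a lower number a stronger inhibitor of growth:
Compound 1 `CCc1cc(=O)c2ccc(OCc3cccc(C(F)(F)F)c3)c(C)c2o1` gives a limit of the assay, > 27600 nM.
Compound 2 `CCc1cc(=O)c2ccc(OC)c(CBr)c2o1` gives a limit of the assay, > 33600 nM.
Compound 3 `CCOc1ccc2c(=O)cc(CC)oc2c1CBr` gives a limit of the assay, > 32100 nM.

Compound 3 therefore stands only at a limit in this assay, as do both other compounds shown (the limit of > 27600 nM in this assay, at which 1 of the 3 values shown sits, (the limit of > 32100 nM in this assay, at which 1 of the 3 values shown sits), (the limit of > 33600 nM in this assay, at which 1 of the 3 values shown sits)). Going by the values given here, the only measured step on a single change, a step that the two limits leave unreadable from compound 2 to compound 3, is not readable from its two limits, so no size is known for the chain lengthening it carries.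

Compound 4 `CCc1cc(=O)c2ccc(OC(C)C)c(CBr)c2o1` differs from compound 3 by methyl in place of hydrogen on a saturated chain carbon bound to an oxygen on an aromatic ring and a saturated chain carbon. Among the compounds with values here, no measured step gives a readable size for such a change, and every value shown is a limit. For compound 4 a further limit is expected, with the estimate 40000 nM and a range of 12000 nM to 150000 nM. The implied step that the limit leaves unreadable from compound 3 to compound 4 is expected to be nominal only, not beyond the scatter.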

Compound 4, concentration for 50% growth inhibition: > 30700 nM
Compound 4 gave a limit, no number; the forecaster's own chance of this, stated with the estimate: 85%; the middle value is on the limit's open side.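

Compound 4 gives only a limit, > 30700 nM, so the steps to compound 4 from compound 2 and compound 3 cannot be read. The compounds shown leave open whether any change among them gives a measurable value in this assay.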